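This account rests on a few compounds, and the source may have more. Where it says the series, first, only, none or still open, it means among the compounds named here.

Measured so far in a functional assay on MCF7 cells (Homo sapiens) for antiproliferative activity, read by MTT assay, with a stated time of 72 h; a higher number here means a weaker inhibitor, a lower number a stronger inhibitor (one line per compound):
- compound 1 `O=S1(=O)C=Cc2ccc(Nc3ccc(C(F)(F)F)cc3)cc21` gives 1270 nM
- compound 2 `N#Cc1cccc(Nc2ccc3c(c2)S(=O)(=O)C=C3)c1` gives > 10000 nM (a limit of the assay, not a number)
- compound 3 `O=S1(=O)C=Cc2cccc(Nc3ccc(OC(F)(F)F)cc3)c21` gives 2690 nM

Of the two actual numbers, compound 3 at 2690 nM is the higher, and compound 1 at 1270 nM lies lower, a gap beyond the scatter.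

Compound 4 `O=S1(=O)C=Cc2cccc(Nc3ccc(Cl)cc3)c21` carries chloro in place of trifluoromethoxy on an aromatic carbon (counted change: chloro in place of trifluoromethoxy on an aromatic carbon). Within the data shown here, no measured pair isolates this change, so in this assay no step beyond the scatter is expected, with compound 3 at 2690 nM as the anchor. The expected step of a 1.1-fold higher number from compound 3 to compound 4 (0.05 log units; within the scatter) is estimated as small. The estimate for compound 4 is 3000 nM (expected range 1200 nM to 7500 nM).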

Compound 4, half-maximal inhibitory concentration: 680 nM
Compound 4: middle estimate off by 4.4-fold (0.64 log units), on the high side; the whole stated range lies above it.
By their numbers in this assay, from the lowest: compounds 4 and 1 (each within the scatter of the next); then compound 3. At a limit, above all of these: compound 2.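

Among these compounds, compounds 3 and 4 form the first pair that differ in one place, giving the first direct reading of this aromatic carbon, para to a large group. In this assay, chloro in place of trifluoromethoxy gives a 4.0-fold lower number from compound 3 to compound 4 (0.60 log units; beyond the scatter), so the number responds to the group held here and the smaller chloro is the better of the two. Nothing measured here accounts for this step.

On these data alone, whether bromo, methoxy or an amine at this position would go lower than chloro remains open. So does whether the step follows the count of heavy atoms or the identity of the group.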